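Widening the ring next to the ether-linked chain

The source may report more compounds than this note shows. Statements on the series, on what has been measured and on what is new or still open speak of the compounds shown alone.

Of the compounds shown here, two have been measured in an assay on HEK293 cells for displacement of a labelled ligand from Neuronal acetylcholine receptor; alpha3/beta4 (Rattus norvegicus), read by scintillation counting; a lower number here means a stronger inhibitor, a higher number a weaker inhibitor. Compound 1 `CCCCC#Cc1cncc(OC[C@@H]2CCN2)c1` gives 1700 nM, the lower of the two numbers, and compound 2 `c1ncc(-c2nnn3c2CCCC3)cc1OC[C@@H]1CCN1` gives 64000 nM, a much higher number, far beyond the scatter of the assay. Compound 2 carries a quite different group on the shared core, so it says little about the change now in question.

The new compound 3 `CCCCC#Cc1cncc(OC[C@@H]2CCCN2)c1` keeps the whole of compound 1 except for one ring: pyrrolidin-2-yl in place of azetidin-2-yl on a saturated chain carbon bound to an oxygen on an aromatic ring. In everyday terms, the ring that holds the basic nitrogen grows by one carbon. For the measured compounds named here, no measured pair in this set shows the same change, so its size here is open. The expectation is a mild weakening, with a fair chance that the step lies within the scatter; the estimated step is a 1.8-fold higher number from compound 1 to compound 3 (0.25 log units; within the scatter). For compound 3 the estimated value in this assay is 3000 nM, with a range from 800 nM to 12000 nM.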

Compound 3, inhibition constant: 18000 nM
For compound 3 the middle estimate is 6.0-fold (0.78 log units) below the measured one; the measured number lies above the stated range.
By their numbers in this assay, from the lowest: compound 1; then compound 3; then compound 2.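

In this assay, replacing azetidin-2-yl with pyrrolidin-2-yl on a saturated chain carbon bound to an oxygen on an aromatic ring gives an 11-fold higher number from compound 1 to compound 3 (1.02 log units; beyond the scatter). For the compounds shown here, this is the first pair in the set that differs in one place only, so it isolates the effect of this ring: one added ring carbon, with the same count of hydrogen-bond donors and acceptors and the rest of compound 1 unchanged, is enough to produce a large step, and of these two rings azetidin-2-yl gives the lower number. Nothing available here accounts for the size of this step.

A single pair cannot show whether the number keeps rising as the ring grows, and a piperidin-2-yl ring, with one carbon more than pyrrolidin-2-yl, would be the next point on that line. Going by these compounds alone, it also remains open whether the same ring change has a step of similar size when the other end of the shared core carries a different group, such as the one in compound 2.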